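Swapping tert-butyl for benzyl on a carbamate oxygen

The compounds below may be only part of what the source reports. "The series", "measured", "known", "first", "only" and "open" are said of these compounds alone.

Four close relatives of one core are compared in a functional assay on ECa-109 cells (Homo sapiens) for inhibition, read by MTT assay, with a stated time of 72 h; a lower number here means a stronger inhibitor, a higher number a weaker inhibitor. Compound 1 `CC(C)(C)OC(=O)N1CCN(C(=S)SCc2cn(Cc3ccc(Cl)c(Cl)c3)nn2)CC1` gives only a limit, > 128000 nM. Compound 2 `O=C(OCc1ccccc1)N1CCN(C(=S)SCc2cn(Cc3ccc(Cl)c(Cl)c3)nn2)CC1` reaches 29400 nM in this assay, and compound 3 `CC(C)(C)OC(=O)N1CCN(C(=S)SCc2cn(Cc3ccccc3Cl)nn2)CC1` reaches 11900 nM. The change from compound 1 to compound 2 is benzyl in place of tert-butyl on an oxygen next to a carbonyl group, and it produced an at least 4.3-fold lower number from compound 1 to compound 2 (0.63 log units; beyond the scatter). The cores of compound 1 and compound 3 differ as 2-chlorophenyl in place of 3,4-dichlorophenyl on a saturated chain carbon bound to an aromatic nitrogen, a change that gave an at least 10-fold lower number from compound 1 to compound 3 (1.03 log units; beyond the scatter). Compound 4 `O=C(OCc1ccccc1)N1CCN(C(=S)SCc2cn(Cc3ccccc3Cl)nn2)CC1` is not yet measured; it differs from compound 3 by benzyl in place of tert-butyl on an oxygen next to a carbonyl group, the same change as that between compound 1 and compound 2, at the same place. The earlier step, an at least 4.3-fold lower number from compound 1 to compound 2 (0.63 log units; beyond the scatter), rests on a limit, so its true size is not fixed. A step of similar size, a 3.0-fold lower number from compound 3 to compound 4 (0.47 log units; beyond the scatter), is expected in this assay. Compound 4 is therefore estimated at 4000 nM, expected between 1200 nM and 12000 nM.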

Compound 4, half-maximal inhibitory concentration: 56800 nM
For compound 4 the middle estimate is 14-fold (1.15 log units) below the measured one; the measured number lies above the stated range.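

In this assay, benzyl in place of tert-butyl does not carry over from one core to the other: on the core of compound 3 it gave a 4.8-fold higher number from compound 3 to compound 4 (0.68 log units; beyond the scatter), opposite in direction to the earlier step: the same change on two cores in this assay, an at least 4.3-fold lower number (0.63 log units; beyond the scatter) from compound 1 to compound 2 and a 4.8-fold higher number (0.68 log units; beyond the scatter) from compound 3 to compound 4, at least 20-fold (1.31 log units) apart, beyond the scatter of two such steps. The other change, 2-chlorophenyl in place of 3,4-dichlorophenyl, does not carry over either, giving a 1.9-fold higher number from compound 2 to compound 4 (0.29 log units; within the scatter) with benzyl present, unlike its step with tert-butyl: the same change on two cores in this assay, an at least 10-fold lower number (1.03 log units; beyond the scatter) from compound 1 to compound 3 and a 1.9-fold higher number (0.29 log units; within the scatter) from compound 2 to compound 4, at least 20-fold (1.31 log units) apart, beyond the scatter of two such steps. Both gaps rest on compound 1, so their true size stays unfixed, and they show that the two changes depend on each other, not why: the limit of > 128000 nM in this assay, at which 1 of the 4 values shown sits.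

As far as these compounds go, it remains open whether this reversal extends to other groups on the carbamate oxygen, such as ethyl or a longer chain. From the compounds shown here alone, it is equally open how a methoxyphenyl in place of the chlorinated rings would behave.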